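Swapping benzyl for 3-chlorophenyl on compound 1

The source may hold more compounds than are shown below. What is called first, only, known or untested is meant among the compounds shown, and "the series" means these compounds.

Values measured in a functional assay on HeLa cells (Homo sapiens) for antiproliferative activity, read by CCK-8 assay, with a stated time of 72 h (a lower number here means a stronger inhibitor, a higher number a weaker inhibitor), are as follows:
- Compound 1 `Nc1ccccc1NC(=O)c1ccc(Cn2cnc3c(NCc4ccccc4)nc(Cl)nc32)cc1` gives 6770 nM here
- Compound 2 `Nc1ccccc1NC(=O)c1ccc(CNc2nc(Cl)nc3c2ncn3C2CCCC2)cc1` gives 3020 nM here
- Compound 3 `Nc1ccccc1NC(=O)c1ccc(COCNc2nc(Nc3ccccc3)c3ncn(C4CCCC4)c3n2)cc1` gives 8700 nM here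

Compound 1 lies within the scatter of compound 3, while compound 2 gives a lower number, beyond the scatter. Among the compounds with values here, compound 4 `Nc1ccccc1NC(=O)c1ccc(Cn2cnc3c(Nc4cccc(Cl)c4)nc(Cl)nc32)cc1` keeps the core of compound 1 but carries 3-chlorophenyl in place of benzyl on a nitrogen on an aromatic ring as its single change. Within the data shown here, no measured pair shows this change alone, so the expectation rests only on the spread of the three values. In this assay the expected step of a 1.4-fold lower number from compound 1 to compound 4 (0.13 log units; within the scatter) stays within the scatter. Compound 4 is expected at 5000 nM (estimated range 1800 nM to 14000 nM).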

Compound 4, half-maximal inhibitory concentration: 11300 nM
Compound 4: middle estimate off by 2.3-fold (0.35 log units), on the low side; low and high end bracket the measured number.
By their numbers in this assay, from the lowest: compound 2; then compounds 1, 3 and 4 (each within the scatter of the next).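

Swapping benzyl for 3-chlorophenyl on a nitrogen on an aromatic ring gives the first readable step at this position in this assay: a 1.7-fold higher number from compound 1 to compound 4 (0.22 log units; within the scatter). Benzylamino and (3-chlorophenyl)amino therefore cannot be told apart here, even though the swap exchanges one carbon for one chlorine in the group. No measured evidence bears on this result. The compounds shown leave open how a plain phenyl, carrying no chlorine, would read at this place on the core of compound 1. They also leave open how a longer chain such as phenethyl, or a morpholine, would read there.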